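A few compounds are considered here, and "the series" means these few. Any claim that something is new, unique, unknown or untested is made for them only; others in the source may bear on it.

Compound 1 `CCN(Cc1ccoc1)C(=O)COc1ccc(C)cc1`: 136 nM
Compound 2 `CCN(Cc1nccs1)C(=O)COc1ccc(C)cc1`: 3060 nM

For the measured compounds named here, in an assay on HEK293 cells for agonist activity at transient receptor potential cation channel subfamily M member 8 (Homo sapiens), read by fluorescence and calcium flux, with a stated time of 15 min (a higher number here means that more compound is needed for the effect, a lower number that less compound is needed), compound 2 gives the higher of the two numbers; compound 1 sits a 23-fold higher number from compound 1 to compound 2 (1.35 log units; beyond the scatter) away, the only step measured so far. Compound 3 `CCN(Cc1cc[nH]n1)C(=O)COc1ccc(C)cc1` is unmeasured. The change from compound 2 is 1H-pyrazol-3-yl in place of 1,3-thiazol-2-yl on a saturated chain carbon bound to an amide-type nitrogen. Going by the values given here, the one known step, from furan-3-yl to 1,3-thiazol-2-yl on that carbon, was large, so swapping one five-membered aromatic ring with 2 hetero atoms for another can move the number far, but the direction for 1H-pyrazol-3-yl is untested. Compound 3 is estimated at 1500 nM, between 300 nM and 8000 nM, which is expected to be a 2.0-fold lower number from compound 2 to compound 3 (0.31 log units; beyond the scatter).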

Compound 3, half-maximal effective concentration: "not active" (no number reported)
For compound 3 the study gives words and no number; no gap can be computed for the estimate.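

For the compounds shown here, compound 3 is reported only in words, as not active, so no step from compound 2 to compound 3 can be read. Nothing shown bears on why. The compounds shown leave open what number, if any, 1H-pyrazol-3-yl would give on this series.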